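The compounds below may be only part of what the source reports. "The series", "measured", "known", "first", "only" and "open" are said of these compounds alone.

Series notes, triazole-linked lactams varied at the aryl group on the ring nitrogen.

Compound 1 `Cc1ccc(-n2cc(CN3C(=O)C[C@@H]4CC[C@@]3(C)C4(C)C)nn2)cc1` gives 400 nM in a functional assay on A549 cells (Homo sapiens) for inhibition, read by MTT assay, with a stated time of 24 h; on this read-out lower numbers stand for stronger inhibition and higher numbers for weaker inhibition. Compound 2 `CC1(C)[C@H]2CC[C@]1(C)N(Cc1cn(-c3ccccc3Br)nn1)C(=O)C2` gives 130 nM, and compound 3 `CC1(C)[C@H]2CC[C@]1(C)N(Cc1cn(-c3ccc(F)cc3)nn1)C(=O)C2` gives 230 nM. Across the three, compound 3 sits with a number between those of compound 1 and compound 2, but neither gap is beyond the scatter: the step of a 1.7-fold lower number from compound 1 to compound 3 (0.24 log units; within the scatter) and the step of a 1.8-fold higher number from compound 2 to compound 3 (0.25 log units; within the scatter) are both within it. Within the data shown here, the only step that stands out is a 3.1-fold lower number from compound 1 to compound 2 (0.49 log units; beyond the scatter), which is modest.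

Compound 4 `CC1(C)[C@H]2CC[C@]1(C)N(Cc1cn(-c3cccc(F)c3)nn1)C(=O)C2` differs from compound 3 as follows: 3-fluorophenyl in place of 4-fluorophenyl on an aromatic nitrogen. The same atoms are present and only the placement of the fluorine on the aryl ring moves.

Among the measured compounds shown here, no measured step moves a substituent around the aryl ring while keeping it the same, so the nearest guidance is indirect: the step of a 1.8-fold higher number from compound 2 to compound 3 (0.25 log units; within the scatter), which swaps one aryl group for another and stays within the scatter, and the step of a 3.1-fold lower number from compound 1 to compound 2 (0.49 log units; beyond the scatter), the only change beyond it. On that basis the step from compound 3 to compound 4 is expected to be a 1.2-fold lower number from compound 3 to compound 4 (0.06 log units; within the scatter), not beyond the scatter, in either direction.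

Compound 4 is therefore estimated at 200 nM, with a range from 80 nM to 500 nM.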

Compound 4, half-maximal inhibitory concentration: 180 nM
The estimate for compound 4 lay 1.1-fold (0.05 log units) above the measured number, within the range that was stated.
By their numbers in this assay, from the lowest: compounds 2, 4, 3 and 1 (each within the scatter of the next, the first and the last beyond it).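

Moving the fluorine from 4-fluorophenyl to 3-fluorophenyl is the first change in the series that relocates one substituent on the aryl ring with its atoms unchanged, and in this assay the two placements are not separated (a 1.3-fold lower number from compound 3 to compound 4 (0.11 log units; within the scatter)). The 3-fluorophenyl group of compound 4 is likewise not separated from the 2-bromophenyl group of compound 2 (a 1.4-fold higher number from compound 2 to compound 4 (0.14 log units; within the scatter)), but it does stand apart from the 4-methylphenyl group of compound 1 (a 2.2-fold lower number from compound 1 to compound 4 (0.35 log units; beyond the scatter)), a modest step, so compound 1 now lies beyond the scatter of two aryl variants. Compound 3 goes against any reading of a general split. It remains within the scatter of compound 1. No measurement at hand accounts for these numbers or explains why the aryl groups fall as they do.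

The compounds shown carry only a halogen or a methyl group on the phenyl ring, so it remains open whether an amine or a carboxylic acid there would keep the number in this range. As far as these compounds go, it is also open whether moving a group other than fluorine around the ring, such as bromine or methyl, would likewise leave the number within the scatter.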